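Swapping a Methyl for a Hydroxy on the Alkyne Side Chain

This account rests on a few compounds, and the source may have more. Where it says the series, first, only, none or still open, it means among the compounds named here.

Of the compounds shown here, two have so far been tested in a functional assay on C6 cells (Homo sapiens) for cytotoxicity against C6 (Rattus norvegicus), with a stated time of 72 h; on this read-out lower numbers stand for stronger inhibition and higher numbers for weaker inhibition. Compound 1 `COc1ccc(Nc2nc(C#CC(C)(C)C)nc(Nc3ccc(OC)cc3)n2)cc1` returned only a limit, > 100000000 nM, and not a true number. Among the compounds with values here, compound 2 `COc1nc(C#CC(C)(C)C)nc(OC)n1` gave 16600 nM, which makes it the only compound with an actual number, so it is the sole anchor for what follows. Compound 3 `COc1nc(C#CC(C)(C)O)nc(OC)n1` changes compound 2 in one place: hydroxy in place of methyl on a saturated chain carbon bound to two saturated chain carbons and a triple-bonded carbon. In words, hydroxy stands in place of methyl on a saturated chain carbon bound to two saturated chain carbons and a triple-bonded carbon, turning tert-butyl into 1-hydroxy-1-methylethyl. Within the data shown here, no measured pair shows what this swap does, so the forecast is loose. A modest weakening in this assay is expected, with the estimated change being a 1.8-fold higher number from compound 2 to compound 3 (0.26 log units; within the scatter). For compound 3 the expected value is 30000 nM, with an estimated range from 8000 nM to 120000 nM.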

Compound 3, half-maximal inhibitory concentration: 15100 nM
Beside the measured number, compound 3's estimate is 2.0-fold (0.30 log units) above it, within the range that was stated.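

In this assay, hydroxy in place of methyl on a saturated chain carbon bound to two saturated chain carbons and a triple-bonded carbon gives a 1.1-fold lower number from compound 2 to compound 3 (0.04 log units; within the scatter). Within the data shown here, this is the first measured pair at this position, and it shows that tert-butyl can become 1-hydroxy-1-methylethyl, which brings in a hydrogen-bond donor and acceptor, with no readable shift in this read-out. Nothing at hand speaks to why the number holds through this swap.

Compound 1 gives only a limit, > 100000000 nM, so it offers no number against which to judge the same swap on its core. As far as these compounds go, whether an amine or a longer chain in this place would also leave the number where it stands remains open.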